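The source may report more compounds than this note shows. Statements on the series, on what has been measured and on what is new or still open speak of the compounds shown alone.

Compound 1 `Cc1cc(C)c(NC(=O)C(C)(C)CCCCCCN2CCCCC2)c2c1CC(C)(C)O2` in an assay for inhibition of acyl-CoA:cholesterol acyltransferase (Oryctolagus cuniculus), using microsomes (a higher number here means a weaker inhibitor, a lower number a stronger inhibitor), gives > 500 nM, which is a limit of the assay and not a number. Compound 2 `Cc1cc(C)c(NC(=O)C(C)(C)CCCCc2ccccc2)c2c1CC(C)(C)O2` gives 210 nM. Compound 3 `Cc1cc(C)c(NC(=O)C(C)(C)CCCOc2ccc(Cl)cc2)c2c1CC(C)(C)O2` gives 260 nM.

Among the two actual numbers compound 3 sits highest, yet its nearest neighbour compound 2 lies close: a 1.2-fold higher number from compound 2 to compound 3 (0.09 log units; within the scatter). Compound 4 `Cc1cc(C)c(NC(=O)C(C)(C)CCCCOc2ccc(Cl)cc2)c2c1CC(C)(C)O2` carries the change ((4-chlorophenoxy)methyl in place of 4-chlorophenoxy on a saturated chain carbon, four bonds along the chain from a carbonyl carbon), so the chain grows by one carbon while the ring and its substituent stay. Within the data shown here, no measured step lengthens the chain in this way; the nearest comparison, a 1.2-fold higher number from compound 2 to compound 3 (0.09 log units; within the scatter), swaps groups at the same chain position and stays within the scatter, and an at least 1.9-fold lower number from compound 1 to compound 3 (0.28 log units; that floor lies within the scatter) only reaches a limit. The step from compound 3 is therefore expected to be small, no change at the digits printed from compound 3 to compound 4 (within the scatter), with no clear direction. Compound 4 is estimated at 260 nM, within 120 nM to 560 nM.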

Compound 4, half-maximal inhibitory concentration: 330 nM
For compound 4 the middle estimate is 1.3-fold (0.10 log units) below the measured one, and the stated range covers the measured number.
By their numbers in this assay, from the lowest: compounds 2, 3 and 4 (each within the scatter of the next). At a limit, above all of these: compound 1.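

In this assay, lengthening the chain by one carbon while the 4-chlorophenoxy ring stays gives no change beyond the scatter (a 1.3-fold higher number from compound 3 to compound 4 (0.10 log units; within the scatter)). At this longer chain, 4-chlorophenoxy in place of phenyl also stays within the scatter (a 1.6-fold higher number from compound 2 to compound 4 (0.20 log units; within the scatter)). Compound 1 gives only a limit of the assay, not a number, so the comparison with it settles no order (an at least 1.5-fold lower number from compound 1 to compound 4 (0.18 log units; that floor lies within the scatter)): the limit of > 500 nM in this assay, at which 1 of the 4 values shown sits.

Still open, going by these compounds, is whether a longer chain than that of compound 4 would keep these numbers. Also open, on these data alone, is what a carboxylic acid or an amine on the ring would do.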